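Substituent changes on the aryloxy end of a chain

The source may report more compounds than this note shows. Statements on the series, on what has been measured and on what is new or still open speak of the compounds shown alone.

Measured compounds in an assay on HEK293 cells for positive allosteric modulation of metabotropic glutamate receptor 2 (Rattus norvegicus), read by thallium flux, with a stated time of 2.5 min; on this read-out higher numbers stand for an effect only at larger amounts of compound and lower numbers for an effect already at smaller amounts:
compound 1 `Cc1c(OCCCCOc2ccc(C(=O)O)cc2)ccc(C(=O)CC2CCCC2)c1O`: 824 nM
compound 2 `Cc1c(OCCCCOc2ccc(C(=O)O)cc2F)ccc(C(=O)CC2CCCC2)c1O`: 639 nM
compound 3 `COc1ccc(C(=O)O)cc1OCCCCOc1ccc(C(=O)CC2CCCC2)c(O)c1C`: 425 nM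

Compound 3 gives the lowest of the three numbers, yet it stands within the scatter of the other two: the step of a 1.9-fold lower number from compound 1 to compound 3 (0.29 log units; within the scatter) and the step of a 1.5-fold lower number from compound 2 to compound 3 (0.18 log units; within the scatter) are both within the usual spread of repeats. Compound 4 `Cc1cc(OCCCCOc2ccc(C(=O)CC3CCCC3)c(O)c2C)ccc1C(=O)O` is not yet measured. It differs from compound 3 in one place: 4-carboxy-3-methylphenyl in place of 5-carboxy-2-methoxyphenyl on an oxygen on a saturated carbon. Within the data shown here, the steps that bear on this change all concern the same aryloxy end of the chain. The step of a 1.3-fold lower number from compound 1 to compound 2 (0.11 log units; within the scatter) and the step of a 1.9-fold lower number from compound 1 to compound 3 (0.29 log units; within the scatter) show that exchanging the substituent pattern on this ring has so far moved the number by amounts within the scatter. Nothing in the three measured compounds suggests that a carboxy and methyl pattern would behave differently, so no step beyond the scatter is expected in this assay. Compound 4 is therefore estimated at 600 nM, with a range from 250 nM to 1500 nM; the expected step is a 1.4-fold higher number from compound 3 to compound 4 (0.15 log units; within the scatter).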

Compound 4, half-maximal effective concentration: 564 nM
The estimate for compound 4 lay 1.1-fold (0.03 log units) above the measured number, and the stated range covers the measured number.
By their numbers in this assay, from the lowest: compounds 3, 4, 2 and 1 (each within the scatter of the next).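

In this assay, compound 4, with its 4-carboxy-3-methylphenyl group, stays within the scatter of the 5-carboxy-2-methoxyphenyl group (a 1.3-fold higher number from compound 3 to compound 4 (0.12 log units; within the scatter)) and of the 4-carboxy-2-fluorophenyl group (a 1.1-fold lower number from compound 2 to compound 4 (0.05 log units; within the scatter)). An added methyl group on the aryl ring, a change not seen among the earlier compounds, gives a 1.5-fold lower number from compound 1 to compound 4 (0.16 log units; within the scatter), so all four aryl groups shown remain within the scatter of one another. Nothing available here explains these small steps.

On these data alone, all four compounds keep a carboxy group on this ring and the same chain, so the effect of a primary amide or a tetrazole in place of that carboxy group remains open. Also open, as far as these compounds go, is what a shorter or longer chain would do in this assay.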